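The source may report more compounds than this note shows. Statements on the series, on what has been measured and on what is new or still open speak of the compounds shown alone.

In an ADME assay on HEK293 cells (Homo sapiens) for cytotoxicity, with a stated time of 6 h (a higher number here means that more compound is tolerated, a lower number that less compound is tolerated), compound 1 (`CCCCNc1nc(N)nc2cccc(CC3CCCC3)c12`) gives only a limit, > 25000 nM. Within the data shown here, compound 2 (`CCCCNc1nc(N)nc2cccc(OCCOC)c12`), with 2-methoxyethoxy in place of cyclopentylmethyl on an aromatic carbon, gives 10000 nM, the only exact number so far. Among the measured compounds shown here, the single measured step, an at least 2.5-fold lower number from compound 1 to compound 2 (0.39 log units; beyond the scatter), is beyond the scatter, but it starts from a limit, so its true size is open: the limit of > 25000 nM in this assay, at which 1 of the 2 values shown sits.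

Compound 3 (`CCCCNc1nc(N)nc2cccc(OCc3ccccc3)c12`) keeps the shared core and turns 2-methoxyethoxy into benzyloxy, with phenyl in place of methoxymethyl on a saturated chain carbon bound to an oxygen on an aromatic ring. For the measured compounds named here, no measured step makes this exact change, so the bearing of an at least 2.5-fold lower number from compound 1 to compound 2 (0.39 log units; beyond the scatter) is indirect. That step removed a ring-bearing group, and compound 3 brings a ring back, so a small move back towards compound 1 and its > 25000 nM seems more likely than a further fall. The expected change is modest, estimated as a 1.4-fold higher number from compound 2 to compound 3 (0.15 log units; within the scatter).

For compound 3 the estimated value in this assay is 14000 nM, with an expected range from 5000 nM to 30000 nM.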

Compound 3, half-maximal cytotoxic concentration: 10000 nM
Compound 3: the middle estimate sits 1.4-fold (0.15 log units) above what was measured; the measured number falls inside the stated range.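

In this assay, exchanging methoxymethyl for phenyl on a saturated chain carbon bound to an oxygen on an aromatic ring gives no change at the digits printed from compound 2 to compound 3 (within the scatter), so adding a six-membered aromatic ring of carbon at this place does not set the two oxygen-linked groups apart. Benzyloxy in place of cyclopentylmethyl gives an at least 2.5-fold lower number from compound 1 to compound 3 (0.39 log units; beyond the scatter), which shows that a ring in the group does not by itself keep the number at the level seen with cyclopentylmethyl, since both of these groups carry one. Neither step against cyclopentylmethyl has a known true size: the limit of > 25000 nM in this assay, at which 1 of the 3 values shown sits.

The compounds shown leave open whether the oxygen on the aromatic ring goes with the lower number, a question on which a cyclopentylmethoxy group, or a benzyl group bound directly to the aromatic carbon, would bear. They also do not tell whether an amine or a carboxylic acid on the saturated chain would read like methoxymethyl and phenyl or would differ from both.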